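Serum half-life notes on compounds 1 to 3

The compounds below may be only part of what the source reports. "The series", "measured", "known", "first", "only" and "open" are said of these compounds alone.

Measured so far:
compound 1 `Cc1cn(C2CC(N=[N+]=[N-])C(COC(=O)OCCCCCCCCO)O2)c(=O)[nH]c1=O` — 0.0333 h
compound 2 `Cc1cn(C2CC(N=[N+]=[N-])C(COC(=O)OCCCCO)O2)c(=O)[nH]c1=O` — 0.5 h

In an ADME assay on the whole organism (serum) with Homo sapiens as the target (a lower number here means that the compound disappears faster, a higher number that the compound lasts longer), compound 1 gives 0.0333 h, the lowest of the two numbers to hand; compound 2 gives 0.5 h. Among the compounds with values here, the one measured step is a 15-fold higher number from compound 1 to compound 2 (1.18 log units; beyond the scatter), a large change for a shortening of the hydroxy-bearing chain on the shared core.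

Compound 3 `Cc1cn(C2CC(N=[N+]=[N-])C(COC(=O)NCCCN)O2)c(=O)[nH]c1=O` is not yet measured. It differs from compound 1 thus: (3-aminopropyl)amino in place of (8-hydroxyoctyl)oxy on a carbonyl carbon. Within the data shown here, the entering group is shorter than the leaving one, which runs in the same direction as the shortening from compound 1 to compound 2, but the change also replaces the oxygen on the carbonyl carbon by a nitrogen and alters the donor and acceptor counts as tallied above, and no measured pair speaks to those parts. Among the measured compounds shown here, the only step on record, a 15-fold higher number from compound 1 to compound 2 (1.18 log units; beyond the scatter), points upward, so an increase beyond the scatter is expected for compound 3, with wide uncertainty. The expected step is a 60-fold higher number from compound 1 to compound 3 (1.78 log units; beyond the scatter). Compound 3 is estimated at 2 h, within 0.3 h to 12 h.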

Compound 3, half-life: > 48 h
Compound 3 gave a limit, no number; the forecaster's own chance of this, stated with the estimate: 10%; middle value at least 24-fold (1.38 log units) away from the limit.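

In this assay compound 3 stands at > 48 h, which is a limit of the assay and not a number. Until now only the length of the hydroxy-bearing chain had been seen to move the half-life, while the group on the carbonyl carbon had kept its oxygen; exchanging that group as a whole now gives an at least 1400-fold higher number from compound 1 to compound 3 (3.15 log units; beyond the scatter) with (3-aminopropyl)amino in place of (8-hydroxyoctyl)oxy, and an at least 96-fold higher number from compound 2 to compound 3 (1.98 log units; beyond the scatter) with (3-aminopropyl)amino in place of 4-hydroxybutoxy. On these data alone, both steps are lower bounds whose true size stays unknown, because the value of compound 3 sits at the top of the measurable range: the limit of > 48 h in this assay, at which 1 of the 3 values shown sits.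

The change from either earlier compound alters the atom on the carbonyl carbon, the end group of the chain and the chain length all at once, and the compounds shown do not tell which of these carries the step. A 3-aminopropoxy group or a (3-hydroxypropyl)amino group on the carbonyl carbon would separate the nitrogen on the carbonyl carbon from the amine of the chain.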